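Solubility Prospects for a Pyridinyl Replacement

This account rests on a few compounds, and the source may have more. Where it says the series, first, only, none or still open, it means among the compounds named here.

Compound 1, `CNC(=O)c1cc(Oc2ccc3nc(Nc4ccccc4)ncc3c2)ccn1`: in a physicochemical assay for solubility, at pH 7 (a lower number here means a less soluble compound, a higher number a more soluble compound), compound 1 gives < 1000 nM, which is a limit of the assay and not a number.
Compound 2, `CNC(=O)c1cc(Oc2ccc3nc(Nc4ccc(OC(F)(F)F)cc4)ncc3c2)ccn1`: in this assay compound 2 gives < 1000 nM, again only a limit.

Compound 2 therefore stands at the limit of this assay, and no actual number is known for it. The step that the two limits leave unreadable from compound 1 to compound 2 cannot be read, since both of its ends sit at the limit of < 1000 nM in this assay, at which 2 of the 2 values shown sit. Compound 3, `CNC(=O)c1cc(Oc2ccc3nc(Nc4ccc(-c5cccnc5)cc4)ncc3c2)ccn1`, differs from compound 2 in one place: pyridin-3-yl in place of trifluoromethoxy on an aromatic carbon. Within the data shown here, no measured step bears on this change, so nothing known sets its size or direction in this assay; a change beyond the scatter in either direction remains possible. Compound 3 is estimated at 1200 nM in this assay, with an expected range from 200 nM to 8000 nM. That estimate corresponds to an expected step of an at least 1.2-fold higher number from compound 2 to compound 3 (0.07 log units; that floor lies within the scatter), itself uncertain given the limit at which the starting point stands.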

Compound 3, solubility: < 1000 nM
Compound 3 gave a limit, no number (the forecaster's own chance of this, stated with the estimate: 50%); middle value at least 1.2-fold (0.07 log units) from the limit.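

The steps from compound 1 and from compound 2 to compound 3 cannot be read in this assay, since all three compounds sit at a limit and not a number: the limit of < 1000 nM in this assay, at which 3 of the 3 values shown sit.

The compounds shown leave open how far the actual values of compound 1, compound 2 and compound 3 lie from that limit, and whether they differ at all.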